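Halogen swap on the benzamide of compound 3

A few compounds are considered here, and "the series" means these few. Any claim that something is new, unique, unknown or untested is made for them only; others in the source may bear on it.

compound 1 `NC(=O)c1c(NC(=O)c2ccccc2Cl)sc2c1CCNC2`: 18600 nM
compound 2 `NC(=O)c1c(NC(=O)c2ccccc2F)sc2c1CCN(Cc1c(Cl)cccc1Cl)C2`: 10300 nM
compound 3 `NC(=O)c1c(NC(=O)c2ccccc2Cl)sc2c1CCN(C(=O)Nc1ccccc1Cl)C2`: 12500 nM

In a functional assay on HL-60 cells (Homo sapiens) for antiproliferative activity, with a stated time of 24 h (on this read-out lower numbers stand for stronger inhibition and higher numbers for weaker inhibition), compound 3 gives 12500 nM, the second highest of the three numbers. Compound 2 gives 10300 nM and compound 1 gives 18600 nM, both within the scatter of compound 3. Compound 4 `NC(=O)c1c(NC(=O)c2ccccc2F)sc2c1CCN(C(=O)Nc1ccccc1Cl)C2` differs from compound 3 by fluoro in place of chloro on an aromatic carbon. Among the measured compounds shown here, the only single-change step measured, a 1.5-fold lower number from compound 1 to compound 3 (0.17 log units; within the scatter), concerns the ring nitrogen and not the halogen, so it bears only loosely on this swap. Compound 2 and compound 3 differ in two places at once, and their two values sit within the scatter of each other. For the measured compounds named here, no measured step therefore points to a shift beyond the scatter; the expected step is a 1.1-fold lower number from compound 3 to compound 4 (0.06 log units; within the scatter). Compound 4 is estimated at 11000 nM, ranging from 5000 nM to 25000 nM.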

Compound 4, half-maximal inhibitory concentration: 32700 nM
Compound 4: the middle estimate sits 3.0-fold (0.47 log units) below what was measured, and the stated range ends below it.
By their numbers in this assay, from the lowest: compounds 2, 3, 1 and 4 (each within the scatter of the next, the first and the last beyond it).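

In this assay, with (2-chlorophenyl)carbamoyl held on the ring nitrogen, the halogen on this aromatic carbon matters: fluoro in place of chloro gives a 2.6-fold higher number from compound 3 to compound 4 (0.42 log units; beyond the scatter) as a step beyond the scatter. With 2-fluorophenyl held, the ring nitrogen also matters, since (2-chlorophenyl)carbamoyl in place of 2,6-dichlorobenzyl gives a 3.2-fold higher number from compound 2 to compound 4 (0.50 log units; beyond the scatter) as the first step there beyond the scatter. On these data alone, whether the halogen swap reads the same with 2,6-dichlorobenzyl on the ring nitrogen stays open, as does the effect of bromo or methoxy at this aromatic carbon. No measured evidence accounts for either step.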